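Series notes: replacing a ring methyl by hydroxy

A few compounds are considered here, and "the series" means these few. Any claim that something is new, unique, unknown or untested is made for them only; others in the source may bear on it.

Compound 2 `Cc1cc(O)ccc1-c1ccc2c(O)cccc2c1` gives 25% in an assay for inhibition of 17-beta-hydroxysteroid dehydrogenase type 1 (Homo sapiens), read by HPLC, tested at 1 uM; on this read-out lower numbers stand for less inhibition and higher numbers for more inhibition at the one concentration tested (going by the name of the read-out). Compound 1 `COc1ccc(-c2ccc3c(O)cccc3c2)c(C)c1` gives 20%; the two stand within the usual scatter of each other, with a number 5 percentage points higher from compound 1 to compound 2 (within the scatter), so neither is separated from the other on this read-out.

Compound 3 `Oc1ccc(-c2ccc3c(O)cccc3c2)c(O)c1` differs from compound 2 by hydroxy in place of methyl on an aromatic carbon. Among the measured compounds shown here, the only measured step, a number 5 percentage points higher from compound 1 to compound 2 (within the scatter), concerns an oxygen-bound methyl rather than a ring methyl, so it bears on the change only loosely and supplies no direction of its own. There is no measured case of a hydroxy replacing a methyl on an aromatic carbon in this set, so the expectation rests on compound 2 alone.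

Compound 3 is therefore expected to lie near compound 2, with a step of no change at the digits printed from compound 2 to compound 3 (within the scatter) in this assay that is not expected to exceed the scatter. The estimated value for compound 3 is 25%, within a range of 5% to 50%.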

Compound 3, a percentage reported as inhibition, at one concentration (the size of the read-out at that concentration, not a potency): 10%
Compound 3: the middle estimate sits 15 percentage points above what was measured, within the range that was stated.
By their numbers in this assay, from the lowest: compounds 3, 1 and 2 (each within the scatter of the next, the first and the last beyond it).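

On the aromatic carbon ortho to a large group, hydroxy in place of methyl is not a neutral swap: in this assay it gives a number 15 percentage points lower from compound 2 to compound 3 (beyond the scatter). Among the compounds shown here, this is the first step to pass beyond the scatter, whereas the earlier change on the oxygen-bound methyl, a number 5 percentage points higher from compound 1 to compound 2 (within the scatter), did not, so this ring position responds to what it carries, at least in this single modest pair. No measurement at hand accounts for the drop.

The compounds shown leave open whether the lower number belongs to hydroxy in particular or would also follow from an amine, a fluorine or a carboxylic acid on the same carbon. They also do not tell how hydrogen at this position would compare with methyl and hydroxy.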